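Aryl ketone exchange on a shared boron-containing core

A few compounds are considered here, and "the series" means these few. Any claim that something is new, unique, unknown or untested is made for them only; others in the source may bear on it.

Measured compounds:
compound 1 `O=C(/C=C/c1ccc2c(c1)B(O)OC2)c1ccco1`: 24100 nM
compound 2 `Cn1cccc1C(=O)/C=C/c1ccc2c(c1)B(O)OC2`: a limit of the assay, > 100000 nM
compound 3 `Cc1ccc(C(=O)/C=C/c2ccc3c(c2)B(O)OC3)cc1`: 10500 nM

In a functional assay on HCT-116 cells (Homo sapiens) for cytotoxicity, read by MTT assay, with a stated time of 48 h (a higher number here means a weaker inhibitor, a lower number a stronger inhibitor), compound 1 gives 24100 nM. For compound 2 the assay reports only a limit, > 100000 nM. Compound 3 gives 10500 nM, the lowest of the two numbers read, with compound 1 as its nearest neighbour. Among the measured steps, a 2.3-fold lower number from compound 1 to compound 3 (0.36 log units; beyond the scatter), whereas an at least 4.1-fold higher number from compound 1 to compound 2 (0.61 log units; beyond the scatter); the two taken together give an at least 9.5-fold lower number from compound 2 to compound 3 (0.97 log units; beyond the scatter), and this is the one case that sits at the limit of > 100000 nM in this assay, at which 1 of the 3 values shown sits.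

Compound 4 `Nc1ccc(C(=O)/C=C/c2ccc3c(c2)B(O)OC3)cc1` keeps the 4-methylphenyl frame of compound 3 but carries a different substituent: amino in place of methyl on an aromatic carbon. For the measured compounds named here, none of the measured steps touches this spot; each of them swaps the whole ring attached to the carbonyl carbon rather than a group on that ring. Going by the values given here, there is therefore no measured step that bears on the change directly, and the expected outcome rests on the scale seen across compound 1 and compound 3. The step is expected to be small, a 1.2-fold higher number from compound 3 to compound 4 (0.09 log units; within the scatter). For compound 4 the estimate in this assay is 13000 nM, with a range from 4000 nM to 45000 nM.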

Compound 4, half-maximal inhibitory concentration: 26100 nM
Compound 4: the middle estimate sits 2.0-fold (0.30 log units) below what was measured, and the stated range covers the measured number.
By their numbers in this assay, from the lowest: compound 3; then compounds 1 and 4 (each within the scatter of the next). At a limit, above all of these: compound 2.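

For the compounds shown here, this is the first measured change on the ring rather than of the whole ring. In this assay, amino in place of methyl, para to a large group, gives a 2.5-fold higher number from compound 3 to compound 4 (0.40 log units; beyond the scatter), so what this position carries does register in the read-out. The 4-aminophenyl and furan-2-yl groups cannot be told apart here: a 1.1-fold higher number from compound 1 to compound 4 (0.03 log units; within the scatter). The 4-aminophenyl group still stands clear of the 1-methyl-1H-pyrrol-2-yl group, with an at least 3.8-fold lower number from compound 2 to compound 4 (0.58 log units; beyond the scatter), but this step rests on a limit for compound 2: the limit of > 100000 nM in this assay, at which 1 of the 4 values shown sits.

The compounds shown leave open whether a hydroxyl, a methoxy or a chloro group at this same place would read closer to compound 3 or to compound 4. They also leave open whether the exchange of methyl for amino would give a step of similar size on another ring.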